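A Methoxy Group Added to the Anilino Ring

A few compounds are considered here, and "the series" means these few. Any claim that something is new, unique, unknown or untested is made for them only; others in the source may bear on it.

Compound 1 `Cc1nc(SCC(=O)Nc2nc(-c3ccc(Cl)cc3)cs2)n(Nc2ccccc2)c1C`: 16200 nM
Compound 2 `Cc1ccc(Nn2c(SCC(=O)Nc3nc(-c4ccccc4)cs3)nc(C)c2C)cc1`: > 100000 nM

Among the measured compounds shown here, in a functional assay on SNB-75 cells (Homo sapiens) for antiproliferative activity, read by sulforhodamine B assay, with a stated time of 48 h (a lower number here means a stronger inhibitor of growth, a higher number a weaker inhibitor of growth), compound 1 gives 16200 nM, the only plain number among the two results. Compound 2 shows > 100000 nM, which is a limit of the assay and not a number; this is the limit of > 100000 nM in this assay, at which 1 of the 2 values shown sits. For the measured compounds named here, compound 2 differs from compound 1 in two places, so no single measured step exists. Compound 3 `COc1ccc(Nn2c(SCC(=O)Nc3nc(-c4ccc(Cl)cc4)cs3)nc(C)c2C)cc1` arises from compound 1 by methoxy in place of hydrogen on an aromatic carbon. The change from compound 1 to compound 3 is expected to weaken growth inhibition by a 1.9-fold higher number from compound 1 to compound 3 (0.27 log units; within the scatter). Compound 3 is expected to give 30000 nM, between 8000 nM and 120000 nM.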

Compound 3, concentration for total growth inhibition: > 100000 nM
Compound 3: no number, only a limit; the forecaster's own chance of this, stated with the estimate: 30%; middle value at least 3.3-fold (0.52 log units) from the limit.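

In this assay, the step from phenyl to 4-methoxyphenyl on the anilino nitrogen, with methoxy in place of hydrogen para to a large group, gives an at least 6.1-fold higher number from compound 1 to compound 3 (0.79 log units; beyond the scatter). This single change is enough to weaken growth inhibition beyond the scatter, so this ring position does not accept methoxy without loss. Compound 3 gives > 100000 nM, which is a limit of the assay and not a number, so the full size of the loss stays unknown: the limit of > 100000 nM in this assay, at which 2 of the 3 values shown sit.

From the compounds shown here alone, whether fluorine or an amine at this same place would keep the growth inhibition of compound 1 remains open. So does the effect of methoxy on another carbon of this ring.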